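Inverting the pyrrolidine stereocentre of an inactive amide

The compounds below may be only part of what the source reports. "The series", "measured", "known", "first", "only" and "open" are said of these compounds alone.

Compound 1 `CC(C)(C)OC(=O)n1cc(-c2ccc(NC(=O)c3ccco3)cc2)nc1N` reaches only a limit in an assay on isolated protein for inhibition of sodium channel protein type 3 subunit alpha (Homo sapiens), read by electrophysiology, with a stated time of 4 min (on this read-out higher numbers stand for weaker inhibition and lower numbers for stronger inhibition), where compound 1 gives > 30000 nM. Compound 2 `CC(C)(C)OC(=O)n1cc(-c2ccc(NC(=O)[C@@H]3CCCN3)cc2)nc1N` likewise reaches only a limit, and in this assay compound 2 gives > 30000 nM. The step that the two limits leave unreadable from compound 1 to compound 2 cannot be sized because of the limit of > 30000 nM in this assay, at which 2 of the 2 values shown sit. Compound 3 `CC(C)(C)OC(=O)n1cc(-c2ccc(NC(=O)[C@H]3CCCN3)cc2)nc1N` differs from compound 2 in that (the two compounds have the same atoms and bonds and differ only in configuration as drawn: 1 of 1 stereo elements differ; a stereocentre at a saturated ring carbon is drawn S in compound 2 and R in compound 3). Among the compounds with values here, no measured step concerns a change of configuration alone, and the one neighbouring step is unreadable, so compound 3 is expected to stay at the limit, with an expected step of a number no higher from compound 2 to compound 3 (the limit leaves the size open). The estimate for compound 3 in this assay is 30000 nM, within 15000 nM to 100000 nM.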

Compound 3, half-maximal inhibitory concentration: > 30000 nM
Compound 3 ended at the assay's limit; the forecaster's own chance of this, stated with the estimate: 90%; the middle value sits exactly at the limit.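

Within the data shown here, no step among compound 1, compound 2 and compound 3 can be read, as all three stop at a limit: the limit of > 30000 nM in this assay, at which 3 of the 3 values shown sit. Left open is whether the configuration separating compound 2 from compound 3 matters at all in this assay at any concentration.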